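A few compounds are considered here, and "the series" means these few. Any claim that something is new, unique, unknown or untested is made for them only; others in the source may bear on it.

The measured compounds in a functional assay on Bel-7402 cells (Homo sapiens) for cytotoxicity, read by MTT assay, with a stated time of 72 h; a higher number here means a weaker inhibitor, a lower number a stronger inhibitor:

Compound 1 `C=C1C(=O)[C@@]23C(=O)OC[C@]4(C(=O)CCC(C)(C)[C@H]4C=O)[C@@H]2CC[C@@H]1[C@H]3O` gives 5030 nM.
Compound 2 `C=C1C(=O)[C@@]23C(=O)OC[C@]4(C(=O)CCC(C)(C)[C@H]4C=O)[C@@H]2CC[C@@H]1[C@H]3OC(C)=O` gives 1730 nM.
Compound 3 `C=C1C(=O)[C@@]23C(=O)OC[C@]4(C(=O)CCC(C)(C)[C@H]4C=O)[C@@H]2CC[C@@H]1[C@H]3OC(=O)c1ccc(OC)cc1` gives 2800 nM.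

Compound 2 has the lowest of the three numbers, yet its standing is only partly secure: a 2.9-fold lower number from compound 1 to compound 2 (0.46 log units; beyond the scatter) lies beyond the scatter, whereas a 1.6-fold higher number from compound 2 to compound 3 (0.21 log units; within the scatter) does not, so compound 2 and compound 3 cannot be told apart on these numbers.

Compound 4 `C=C1C(=O)[C@@]23C(=O)OC[C@]4(C(=O)CCC(C)(C)[C@H]4C=O)[C@@H]2CC[C@@H]1[C@H]3OC(=O)c1ccc(Cl)cc1` is the next member, and it differs from compound 2 by 4-chlorophenyl in place of methyl on a carbonyl carbon. Among the compounds with values here, the one step that bears on this is the one in which the same methyl was exchanged for an aryl group, a 1.6-fold higher number from compound 2 to compound 3 (0.21 log units; within the scatter), together with the weaker bound from compound 1, a 1.8-fold lower number from compound 1 to compound 3 (0.25 log units; within the scatter), both within the scatter. Compound 4 is therefore expected to sit close to compound 2 in this assay, with a step of about a 1.3-fold higher number from compound 2 to compound 4 (0.12 log units; within the scatter) that need not exceed the scatter. The expected number for compound 4 is 2300 nM, within a range of 1100 nM to 5000 nM.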

Compound 4, half-maximal inhibitory concentration: 3840 nM
Estimate against measurement, compound 4: 1.7-fold (0.22 log units) below, and the stated range covers the measured number.
By their numbers in this assay, from the lowest: compounds 2, 3, 4 and 1 (each within the scatter of the next, the first and the last beyond it).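

In this assay, exchanging the methyl on the carbonyl carbon for 4-chlorophenyl (a 2.2-fold higher number from compound 2 to compound 4 (0.35 log units; beyond the scatter)) gives the first step from compound 2 to an aryl group that passes the scatter, which the 4-methoxyphenyl of compound 3 did not do. Chloro in place of methoxy on the aromatic carbon (a 1.4-fold higher number from compound 3 to compound 4 (0.14 log units; within the scatter)) stays within the scatter, so compound 3 and compound 4 cannot be told apart. The (4-chlorophenyl)carbonyl group in place of hydrogen on the oxygen (a 1.3-fold lower number from compound 1 to compound 4 (0.12 log units; within the scatter)) also stays within the scatter, so among the three acylated compounds only the acetyl of compound 2 stands clear of the free hydroxyl of compound 1.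

The compounds shown leave open how a longer chain such as propanoyl, or an acyl group carrying an amine, would read on the same oxygen. Nothing shown accounts for these steps.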